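The source may hold more compounds than are shown below. What is called first, only, known or untested is meant among the compounds shown, and "the series" means these compounds.

Measured in a physicochemical assay for solubility, read by HPLC, in phosphate buffer, at pH 6.5; a higher number here means a more soluble compound, a lower number a less soluble compound:
Compound 1 `COC(=O)C1=C(CN2CC3CC2CO3)NC(c2nccs2)=NC1(C)c1ccc(F)cc1`: 564 ug/mL
Compound 2 `COC(=O)C1=C(CN2CCNC(=O)C2)NC(c2nccs2)=NC1(C)c1ccc(F)cc1`: 34 ug/mL

Of these two, compound 2 stands lowest, at 34 ug/mL. Compound 3 `COC(=O)C1=C(CN2CCC(F)(F)CC2)NC(c2nccs2)=NC1(C)c1ccc(F)cc1` differs from it at one place: 4,4-difluoropiperidin-1-yl in place of 3-oxopiperazin-1-yl on a saturated chain carbon bound to a double-bonded ring carbon. Among the measured compounds shown here, only one measured step bears on this place, a 17-fold lower number from compound 1 to compound 2 (1.22 log units; beyond the scatter). For the measured compounds named here, that step was large, so changes here can matter, but 4,4-difluoropiperidin-1-yl appears in no measured compound, and the step gives no firm direction. In this assay, only a small step is expected, a 1.7-fold lower number from compound 2 to compound 3 (0.23 log units; within the scatter). For compound 3 the estimate is 20 ug/mL, with an expected range from 4 ug/mL to 100 ug/mL.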

Compound 3, solubility: < 1 ug/mL
Compound 3: no number, only a limit (the forecaster's own chance of this, stated with the estimate: 10%); middle value at least 20-fold (1.30 log units) away from the limit.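

In this assay, 4,4-difluoropiperidin-1-yl in place of 3-oxopiperazin-1-yl gives an at least 34-fold lower number from compound 2 to compound 3 (1.53 log units; beyond the scatter), so a swap between these two six-membered rings on the saturated chain carbon can alone produce a large step. The widest step at this place is an at least 560-fold lower number from compound 1 to compound 3 (2.75 log units; beyond the scatter). Compound 3 stands at a limit and not at a number: the limit of < 1 ug/mL in this assay, at which 1 of the 3 values shown sits.

As far as these compounds go, the true value of compound 3 stays open. So does whether piperidin-1-yl without the two fluorine atoms, or morpholin-4-yl, would fall nearer compound 1 or compound 3 at this place.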